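Cyclohexyl in Place of Cyclopentyl on the Shared Core

The source may hold more compounds than are shown below. What is called first, only, known or untested is meant among the compounds shown, and "the series" means these compounds.

In a functional assay on K562 cells (Homo sapiens) for inhibition, read by trypan blue exclusion, with a stated time of 72 h (a higher number here means a weaker inhibitor, a lower number a stronger inhibitor), compound 1 (`Cn1c(=O)c(S(=O)(=O)c2ccc(F)cc2F)cc2cnc(Nc3ccc4[nH]c(C(=O)O)cc4c3)nc21`) gives 10000 nM, and compound 2 (`COc1ccc(Nc2ncc3cc(S(=O)(=O)c4ccc(C)cc4)c(=O)n(C)c3n2)cc1`) gives 75000 nM. Compound 3 (`O=c1c(S(=O)(=O)c2ccc(F)cc2F)cc2cnc(Nc3ccc4[nH]ccc4c3)nc2n1C1CCCC1`) gives 5000 nM, a value within the scatter of compound 1 and beyond the scatter on the stronger side of compound 2. Compound 4 (`O=c1c(S(=O)(=O)c2ccc(F)cc2F)cc2cnc(Nc3ccc4[nH]ccc4c3)nc2n1C1CCCCC1`) carries cyclohexyl in place of cyclopentyl on an aromatic nitrogen. Going by the values given here, no measured pair shows this change on its own, so the expectation in this assay is cautious, with no step beyond the scatter in either direction. The expected step, a 1.2-fold higher number from compound 3 to compound 4 (0.08 log units; within the scatter), is therefore small. Compound 4 is estimated at 6000 nM, with an expected range of 2000 nM to 15000 nM.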

Compound 4, half-maximal inhibitory concentration: 10000 nM
Compound 4: middle estimate off by 1.7-fold (0.22 log units), on the low side; low and high end bracket the measured number.
By their numbers in this assay, from the lowest: compounds 3, 1 and 4 (each within the scatter of the next); then compound 2.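

In this assay, going by these compounds alone, the change from cyclopentyl to cyclohexyl on the aromatic nitrogen gives a 2.0-fold higher number from compound 3 to compound 4 (0.30 log units; within the scatter) and is the first step that can be read at this position. On this shared core, the two carbon rings cannot be told apart in this assay. No evidence here gives a reason for this result. From the compounds shown here alone, whether an amine or a longer chain on this nitrogen would stay within the scatter of compound 3 remains open. So does whether the same change would give a similar step with other groups on the shared core.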